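The source may report more compounds than this note shows. Statements on the series, on what has been measured and on what is new or still open speak of the compounds shown alone.

Measured compounds:
- compound 1, `Cc1c(C(=O)c2ccccc2)oc2ccc(NS(=O)(=O)c3ccc(F)cc3)cc12`: 34800 nM
- compound 2, `Cc1c(C(=O)c2ccccc2)oc2ccc(NC(=O)c3ccc(F)cc3)cc12`: 15600 nM

Both compounds were tested in a functional assay on NCI-H460 cells (Homo sapiens) for antiproliferative activity, read by MTT assay, with a stated time of 48 h; on this read-out lower numbers stand for stronger inhibition and higher numbers for weaker inhibition. Compound 1 gives 34800 nM, the highest number of the two, and so the weakest inhibition shown here. The nearest number belongs to compound 2 with 15600 nM; the gap between these two lies beyond the usual scatter, so compound 2 inhibits growth more strongly than compound 1. Among the compounds with values here, no step between them is described in terms of a single structural change, so their two values are all that can be said of them.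

Compound 3, `CCOC(=O)c1oc2ccc(NS(=O)(=O)c3ccc(F)cc3)cc2c1C`, is not yet measured. It differs from compound 1 in one place: ethoxy in place of phenyl on a carbonyl carbon. Cut one bond further out, the change reads benzoyl to ethoxycarbonyl. Within the data shown here, nothing among the measured compounds shows what such a change does in this assay, so the expected step from compound 1 to compound 3 is uncertain in size and direction, and a change no larger than the scatter is as plausible as a real shift. The estimated step is a 1.3-fold higher number from compound 1 to compound 3 (0.11 log units; within the scatter). For compound 3 the expected value is 45000 nM, with a wide range from 12000 nM to 170000 nM.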

Compound 3, half-maximal inhibitory concentration: 8890 nM
Estimate against measurement, compound 3: 5.1-fold (0.70 log units) above; the measured number lies below the stated range.
By their numbers in this assay, from the lowest: compounds 3 and 2 (each within the scatter of the next); then compound 1.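

The carbonyl carbon's substituent clearly matters for growth inhibition: in this assay, putting ethoxy in place of phenyl gives a 3.9-fold lower number from compound 1 to compound 3 (0.59 log units; beyond the scatter) and so turns benzoyl into ethoxycarbonyl with a real gain rather than a loss. For this pair, then, the phenyl ring is not required for the activity seen with compound 1, and a smaller group without a ring, carrying a hydrogen-bond acceptor, does better on the same core. Nothing available here accounts for the gain, and this single pair cannot separate the loss of the ring from the arrival of the oxygen.

Other groups on the same carbonyl carbon, such as acetyl, a carboxylic acid or a longer ester chain like butoxycarbonyl, would be needed to show which of these changes carries the effect and how far it extends. From the compounds shown here alone, it also remains open whether the same swap would give a similar step on the amide-linked compound 2, since a single pair cannot show whether the effect holds beyond the sulfonamide series.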